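The source may hold more compounds than are shown below. What is called first, only, known or untested is meant among the compounds shown, and "the series" means these compounds.

Measured compounds:
- compound 1, `COc1cc(/C=C/C(=O)c2cccc(O)c2)ccc1O`: 94%
- compound 2, `COc1ccc(/C=C/C(=O)c2ccc(OC)c(OC)c2)cc1OC`: 91.9%
- compound 3, `COc1ccc(/C=C/C(=O)c2cccc(O)c2)cc1OC`: 91%

All three were examined in an ADME assay on RAW264.7 cells (Mus musculus) for cytotoxicity, read by MTT assay, with a stated time of 24 h, tested at 2.5 ug/mL; on this read-out lower numbers stand for a stronger effect and higher numbers for a weaker effect at the one concentration tested. In this assay compound 1 gives 94%, compound 2 gives 91.9% and compound 3 gives 91%. These three numbers lie within the usual scatter of one another, so none of the compounds can be set apart from the others on this evidence.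

Compounds 3 and 1 differ in one place only, by hydrogen in place of methyl on an oxygen on an aromatic ring. That change gave a number 3 percentage points higher from compound 3 to compound 1 (within the scatter), a step that stays within the scatter. Compound 2 and compound 3 share the same kind of skeleton, but the difference between the two cores is not broken down here.

Compound 4, `COc1ccc(/C=C/C(=O)c2ccc(OC)c(OC)c2)cc1O`, has not yet been measured. It differs from compound 2 by hydrogen in place of methyl on an oxygen on an aromatic ring, the same change that was made from compound 3 to compound 1, with the place described in the same words in both cases. Since the earlier step was a number 3 percentage points higher from compound 3 to compound 1 (within the scatter), the expectation for compound 4 is a step of a number 1.1 percentage points higher from compound 2 to compound 4 (within the scatter), which also stays within the scatter. In this assay compound 4 is therefore expected to give about 93%, with a likely span from 85% to 100%.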

Compound 4, a percentage reported as activity, at one concentration (the size of the read-out at that concentration, not a potency): 82.1%
Compound 4: middle estimate off by 10.9 percentage points, on the high side, outside the stated range (below it).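

Replacing methoxy with hydroxy on the core of compound 2 gave a number 9.8 percentage points lower from compound 2 to compound 4 (within the scatter), so in this assay this step alone cannot be told apart from the ordinary variation between repeated measurements. Comparing the same change on two cores is the direct way to test whether it carries from one to the other, and here the two steps cannot be separated: the same change on two cores in this assay, a number 3 percentage points higher (within the scatter) from compound 3 to compound 1 and a number 9.8 percentage points lower (within the scatter) from compound 2 to compound 4, 12.8 percentage points apart, within the scatter of two such steps This shows no measurable difference in how the change behaves on the two cores, but it does not show that the change has the same size on both, or that it has any real effect on either, since each core offers only one pair of compounds and each step is small relative to the scatter.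

What the compounds shown leave open is whether any other group on that oxygen, such as a longer chain like propyl or a chain ending in an amine or a carboxylic acid, would give a step that stands clear of the scatter. They also leave open whether methoxy to hydroxy would give a clearer result on a third core or at another concentration.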